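A chlorine for a methyl on the sulfonyl arm

This account rests on a few compounds, and the source may have more. Where it says the series, first, only, none or still open, it means among the compounds named here.

Compound 1 `Cc1ccccc1S(=O)(=O)Nc1ccc2oc(-c3ccccc3)nc2c1` is the starting point of this step. In an ADME assay on HEK293 cells (Homo sapiens) for cytotoxicity, read by resazurin assay, with a stated time of 48 h (a higher number here means that more compound is tolerated, a lower number that less compound is tolerated), compound 1 gives 57000 nM. Two further compounds share the benzoxazole-free description of a sulfonamide core with compound 1 only in part. Compound 2 `Cc1ccccc1S(=O)(=O)Nc1ccc(-c2nc3ccccc3o2)cc1` reaches only a limit of this assay at > 100000 nM. Compound 3 `O=S(=O)(Nc1ccc(-c2nc3ccccc3o2)cc1)c1ccc(Cl)s1` likewise reaches only a limit at > 100000 nM. Within the data shown here, the one measured step between them, a step that the two limits leave unreadable from compound 2 to compound 3, cannot be read, so it tells nothing about the size of a change on the sulfonyl sulfur. Among the measured compounds shown here, compound 1 therefore stands as the only measured number, the other two values being (the limit of > 100000 nM in this assay, at which 2 of the 3 values shown sit).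

Compound 4 `O=S(=O)(Nc1ccc2oc(-c3ccccc3)nc2c1)c1cccc(Cl)c1` differs from compound 1 by 3-chlorophenyl in place of 2-methylphenyl on a sulfonyl sulfur. For the measured compounds named here, no measured step bears directly on this change, and the one step on the same position is unreadable. The expectation is therefore no step beyond the usual scatter. Compound 4 is expected to give about 57000 nM, within a range from 25000 nM to 130000 nM. The step this estimate means is no change at the digits printed from compound 1 to compound 4 (within the scatter).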

Compound 4, half-maximal cytotoxic concentration: 70000 nM
For compound 4 the middle estimate is 1.2-fold (0.09 log units) below the measured one; low and high end bracket the measured number.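

In this assay, among these compounds, the change of 2-methylphenyl to 3-chlorophenyl on a sulfonyl sulfur gives the first readable step at this position: a 1.2-fold higher number from compound 1 to compound 4 (0.09 log units; within the scatter). This swap of one aromatic carbon ring for another therefore leaves compound 1 and compound 4 indistinguishable in this read-out, though a single pair on one core supports no general rule for the position. The earlier step at this position, on the core shared by compound 2 and compound 3, cannot be read, so it offered no such comparison: the limit of > 100000 nM in this assay, at which 2 of the 4 values shown sit.

As far as these compounds go, it remains open how 5-chlorothiophen-2-yl would read on the core of compound 1. Also open, from the compounds shown here alone, is whether a phenyl ring carrying an amine or a carboxylic acid on the sulfonyl sulfur would give a step beyond the scatter.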